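From Chloro to Methoxy: Expected Cytotoxicity of Compound 3

The compounds below may be only part of what the source reports. "The series", "measured", "known", "first", "only" and "open" are said of these compounds alone.

Measured so far:
compound 1, `O=C(Nc1ccc(Cl)cc1)c1c(NCCO)cc(-c2cccc(Br)c2)oc1=O`: 17000 nM
compound 2, `O=C(Nc1ccc(Cl)cc1)c1c(NCCO)cc(-c2ccc(Br)cc2)oc1=O`: > 20000 nM

In an ADME assay on Huh-7 cells (Homo sapiens) for cytotoxicity, with a stated time of 3 days (on this read-out higher numbers stand for lower toxicity in this test and lower numbers for higher toxicity in this test), compound 1 gives 17000 nM. Compound 2 gives only a limit of this assay, > 20000 nM, so its exact value is not known and it stands at the edge of what the test reports, as noted in the limit of > 20000 nM in this assay, at which 1 of the 2 values shown sits. Among the compounds with values here, the single measured step, an at least 1.1-fold higher number from compound 1 to compound 2 (0.07 log units; that floor lies within the scatter), concerns only where the bromine sits on one ring.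

Compound 3, `COc1ccc(NC(=O)c2c(NCCO)cc(-c3ccc(Br)cc3)oc2=O)cc1`, differs from compound 2 elsewhere: methoxy in place of chloro on an aromatic carbon. Within the data shown here, no measured step touches this part of the shared core, so the expectation rests only on the fact that the one measured change left the read-out within the scatter. The step from compound 2 to compound 3 is therefore expected to be small, a number no higher from compound 2 to compound 3 (the limit leaves the size open). Compound 3 is expected to give about 20000 nM, between 8000 nM and 50000 nM.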

Compound 3, half-maximal cytotoxic concentration: > 20000 nM
Compound 3: a limit, no number; the forecaster's own chance of this, stated with the estimate: 60%; the middle value sits exactly at the limit.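

Compound 2 and compound 3 each give only a limit, not a number, so no step can be read between them: the limit of > 20000 nM in this assay, at which 2 of the 3 values shown sit. Whether methoxy in place of chloro shifts the cytotoxicity read-out at all, and by how much, stays open in the compounds shown.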